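Removing the Butyl Chain from Compound 1

The source may report more compounds than this note shows. Statements on the series, on what has been measured and on what is new or still open speak of the compounds shown alone.

For the measured compounds named here, compound 1 `CCCCc1nc(N)c2nc(O)n(Cc3ccccc3)c2n1` is the only compound here with a firm number: in a functional assay on the whole organism for activation, with Mus musculus as the target (on this read-out higher numbers stand for an effect only at larger amounts of compound and lower numbers for an effect already at smaller amounts), compound 1 gives 0.3 mg/kg. Compound 2 `Nc1nc(SCc2ccccc2)nc2c1nc(O)n2Cc1ccccc1` shows only a limit of this assay, > 1 mg/kg. Going by the values given here, the single measured step, an at least 3.3-fold higher number from compound 1 to compound 2 (0.52 log units; beyond the scatter), changes the same butyl group that is at issue now. Compound 3 `Nc1ncnc2c1nc(O)n2Cc1ccccc1` differs from compound 1 by hydrogen in place of butyl on an aromatic carbon. That one known change at this carbon weakened the effect, so a higher number is expected for compound 3 as well, meaning a step of a 3.3-fold higher number from compound 1 to compound 3 (0.52 log units; beyond the scatter). Compound 3 is therefore estimated at 1 mg/kg, with a range from 0.3 mg/kg to 3 mg/kg.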

Compound 3, minimum effective dose: 30 mg/kg
Beside the measured number, compound 3's estimate is 30-fold (1.48 log units) below it, outside the stated range (above it).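

Taking the butyl group away and leaving only hydrogen on this aromatic carbon gives a 100-fold higher number from compound 1 to compound 3 (2.00 log units; beyond the scatter), so in this assay much of the effect of compound 1 goes with this chain. This puts a size on the loss at this position, which the earlier step could only bound. Compound 2 gives only a limit, so its step to compound 3 cannot be read, and how benzylsulfanyl ranks against hydrogen stays unknown: the limit of > 1 mg/kg in this assay, at which 1 of the 3 values shown sits.

On these data alone, whether a shorter chain such as ethyl, a longer chain such as hexyl, or an amine on this carbon would match butyl remains open.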